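Swapping the chain-end amine for a pyrrole

The source may hold more compounds than are shown below. What is called first, only, known or untested is meant among the compounds shown, and "the series" means these compounds.

- Compound 1 `Cn1cc(C2=C(c3nn(CCCN4CCCCC4)c4ncccc34)C(=O)N(c3ccccc3)C2=O)c2ccccc21` gives 3790 nM as its measured value
- Compound 2 `CN(C)CCCn1nc(C2=C(c3cn(C)c4ccccc34)C(=O)N(c3ccccc3)C2=O)c2cccnc21` gives 1700 nM as its measured value

Both numbers come from a functional assay on K562 cells (Homo sapiens) for antiproliferative activity, read by MTT assay, with a stated time of 48 h (on this read-out higher numbers stand for weaker inhibition and lower numbers for stronger inhibition), and compound 2 holds the lower of the two, which makes it the stronger inhibitor of this small pair.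

The next compound to be tested is compound 3 `Cn1cc(C2=C(c3nn(CCCn4cccc4)c4ncccc34)C(=O)N(c3ccccc3)C2=O)c2ccccc21`, and it differs from compound 2 at the end of its chain: 1H-pyrrol-1-yl in place of dimethylamino on a saturated chain carbon, three bonds along the chain from an aromatic nitrogen with the whole change reading 1H-pyrrol-1-yl in place of dimethylamino on a saturated chain carbon, three bonds along the chain from an aromatic nitrogen.

For the measured compounds named here, only one measured step touches this place, namely a 2.2-fold lower number from compound 1 to compound 2 (0.35 log units; beyond the scatter) and it is modest, though beyond the scatter. In that step dimethylamino gave the lower number, so replacing it here is expected to raise the number, not lower it. One step is thin evidence, however, and no pyrrole has yet been measured. The expectation is a 2.2-fold higher number from compound 2 to compound 3 (0.35 log units; beyond the scatter) as a modest loss, held with wide uncertainty. For compound 3 the estimated value is 3800 nM and the expected range runs from 1500 nM to 10000 nM as its two ends.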

Compound 3, half-maximal inhibitory concentration: 36600 nM
Compound 3: the middle estimate sits 9.6-fold (0.98 log units) below what was measured, outside the stated range (above it).
By their numbers in this assay, from the lowest: compound 2; then compound 1; then compound 3.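

In this assay, the end of this chain matters far more than the first pair suggested: 1H-pyrrol-1-yl in place of dimethylamino gives a 22-fold higher number from compound 2 to compound 3 (1.33 log units; beyond the scatter), a large step, whereas dimethylamino and piperidin-1-yl differed only modestly. Set against piperidin-1-yl, the same pyrrole gives a 9.7-fold higher number from compound 1 to compound 3 (0.98 log units; beyond the scatter), so the loss appears from both amine-ended compounds, and compound 3 carries the highest number of the three, with both of its steps beyond the scatter. No measurement shown here explains the size of this loss.

From the compounds shown here alone, what remains open is whether the loss follows the aromatic ring itself: a pyrrolidin-1-yl end, the saturated five-membered counterpart of the pyrrole, would test that directly, and an imidazol-1-yl end would show what a second ring nitrogen does. Also open, going by these compounds, is how far these differences depend on the chain, which a shorter or longer chain carrying the same dimethylamino end would help to settle.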